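The source may report more compounds than this note shows. Statements on the series, on what has been measured and on what is new or still open speak of the compounds shown alone.

Three compounds were measured in an assay on isolated protein for inhibition of A disintegrin and metalloproteinase with thrombospondin motifs 5 (Homo sapiens), read by spectrophotometry, with stated times of 10 min and 3 h; on this read-out higher numbers stand for weaker inhibition and lower numbers for stronger inhibition:

Compound 1 `O=C(COc1ccccc1)NNC(=S)NCc1ccc(-c2ccccc2)cc1` gives 10000 nM
Compound 2 `O=C(COc1ccc(C(F)(F)F)cc1)NNC(=S)NCc1ccc(-c2ccccc2)cc1` gives 1700 nM
Compound 3 `O=C(COc1ccc(C(F)(F)F)cc1)NNC(=S)NCCCCC1CCCCC1` gives 540 nM

Between compound 2 and compound 1 the only change is hydrogen in place of trifluoromethyl on an aromatic carbon, and this gave a 5.9-fold higher number from compound 2 to compound 1 (0.77 log units; beyond the scatter). Compound 3 and compound 2 share the same part carrying the trifluoromethyl, but the difference between their two cores is not broken down here. Compound 3 has the lowest number of the three.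

Compound 4 `O=C(COc1ccccc1)NNC(=S)NCCCCC1CCCCC1` is not yet measured. It differs from compound 3 by hydrogen in place of trifluoromethyl on an aromatic carbon, the same change at the same place as from compound 2 to compound 1. The expected step in this assay is therefore a 5.9-fold higher number from compound 3 to compound 4 (0.77 log units; beyond the scatter), resting on the earlier 5.9-fold higher number from compound 2 to compound 1 (0.77 log units; beyond the scatter) applied to compound 3 with its 540 nM. Compound 4 is estimated at 3200 nM, expected to fall between 1400 nM and 8000 nM.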

Compound 4, half-maximal inhibitory concentration: > 100000 nM
Compound 4: no number, only a limit; the forecaster's own chance of this, stated with the estimate: 10%; middle value at least 31-fold (1.49 log units) away from the limit.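

Hydrogen in place of trifluoromethyl gave an at least 180-fold higher number from compound 3 to compound 4 (2.26 log units; beyond the scatter) in this assay, and the size of this step did not carry over from one core to the other: the same change on two cores in this assay, a 5.9-fold higher number (0.77 log units; beyond the scatter) from compound 2 to compound 1 and an at least 180-fold higher number (2.26 log units; beyond the scatter) from compound 3 to compound 4, at least 31-fold (1.49 log units) apart, beyond the scatter of two such steps. From the compounds shown here alone, compound 4 gives > 100000 nM, which is a limit of the assay and not a number, so the full size of its step remains unknown. On both cores the number rose with this change, but two cores do not establish a general rule, and these data do not explain why the size differs.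

Going by these compounds, it remains open whether a chlorine atom or a methoxy group in the same place would retain the inhibition seen with trifluoromethyl. On these data alone, it is also open how this change would behave with a shorter chain in place of the cyclohexylbutyl group.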